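A few compounds are considered here, and "the series" means these few. Any claim that something is new, unique, unknown or untested is made for them only; others in the source may bear on it.

Compound 1 `CCOC(=O)N1[C@@H]2C=C[C@@](OC)(C(=O)c3c2cc(OC)c(OC)c3OCC)N1C(=O)OCC`: > 300 ug/mL
Compound 2 `COc1cc2c(c(OCc3ccc(Cl)cc3)c1OC)C(=O)[C@]1(OC)C=C[C@H]2N(C(=O)OCC(C)C)N1C(=O)OCC(C)C`: 42 ug/mL

Both compounds were tested in an ADME assay on KB cells (Homo sapiens) for cytotoxicity; a higher number here means that more compound is needed for the effect, a lower number that less compound is needed. Compound 1 gives > 300 ug/mL, which is a limit of the assay and not a number. Its true position is therefore unknown, and any step that starts from it can only be judged loosely. Compound 2 gives a real number, 42 ug/mL, so this assay can return measurable values for compounds of this set.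

Compound 3 `CCOC(=O)N1[C@@H]2C=C[C@@](OC)(C(=O)c3c2cc(OC)c(OC)c3OCc2ccccc2)N1C(=O)OCC` keeps the core of compound 1 and changes it in one place: phenyl in place of methyl on a saturated chain carbon bound to an oxygen on an aromatic ring. In plain terms, ethoxy becomes benzyloxy, with phenyl in place of methyl on a saturated chain carbon bound to an oxygen on an aromatic ring.

Among the measured compounds shown here, no measured pair isolates this change, so the expectation rests on little. For the measured compounds named here, the only firm number is compound 2 at 42 ug/mL, and the expectation leans towards it. The expected change, an at least 2.5-fold lower number from compound 1 to compound 3 (0.39 log units; beyond the scatter), is a moderate one towards less compound being needed, though compound 3 may also stay at the limit. For compound 3 the estimate is 120 ug/mL, with an expected range of 40 ug/mL to 300 ug/mL.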

Compound 3, concentration for half-maximal effect: 215 ug/mL
Compound 3: middle estimate off by 1.8-fold (0.25 log units), on the low side; low and high end bracket the measured number.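

With ethoxy changed to benzyloxy, the core of compound 1 gives a measured number in this assay: compound 3 reaches 215 ug/mL. Compound 1 gives > 300 ug/mL, which is a limit of the assay and not a number. The change can therefore be stated only as a floor, an at least 1.3-fold lower number from compound 1 to compound 3 (0.14 log units; that floor lies within the scatter), and since that floor does not clear the usual scatter, the true step could be small or much larger, because one end of it rests on a limit: the limit of > 300 ug/mL in this assay, at which 1 of the 3 values shown sits.

Among compounds that differ only in this place, just methyl and phenyl are seen on the saturated chain carbon, so it remains open how a longer chain such as propyl, or a phenyl ring carrying an amine or a carboxylic acid, would read in this assay. Compound 2 also has a different group on this oxygen, but it differs from compound 3 in more than one place, so it cannot show what that group alone does.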